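The compounds below may be only part of what the source reports. "The series", "measured", "known", "first", "only" and "open" are said of these compounds alone.

Measured so far:
compound 1, `Cc1ccc2c(c1)/C(=C1/Nc3ccccc3/C1=N\O)C(=O)N2Cc1ccc(/C=C/C(=O)NO)cc1`, 50 nM;
compound 2, `COc1ccc2c(c1)/C(=C1/Nc3ccccc3/C1=N\O)C(=O)N2Cc1ccc(C(=O)NO)cc1`, 40 nM.

In a functional assay on SW-620 cells (Homo sapiens) for cytotoxicity, read by colorimetric assay (on this read-out lower numbers stand for stronger inhibition and higher numbers for weaker inhibition), compound 2 gives 40 nM, and its nearest neighbour in number, compound 1, gives 50 nM; the two lie within the usual scatter of each other, so neither can be called more potent. Compound 3, `Cc1ccc2c(c1)/C(=C1/Nc3ccccc3/C1=N\O)C(=O)N2Cc1ccc(C(=O)NO)cc1`, differs from compound 2 in one place: methyl in place of methoxy on an aromatic carbon. Among the compounds with values here, no measured pair shows the effect of such a swap here. A change this small is expected to shift this assay little, if at all, beyond the scatter: the estimated step of a 1.3-fold higher number from compound 2 to compound 3 (0.10 log units; within the scatter) is essentially flat. Compound 3 is therefore expected to give about 50 nM, within 20 nM to 120 nM.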

Compound 3, half-maximal inhibitory concentration: 30 nM
The estimate for compound 3 lay 1.7-fold (0.22 log units) above the measured number, and the stated range covers the measured number.
By their numbers in this assay, from the lowest: compounds 3, 2 and 1 (each within the scatter of the next).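

In this assay the swap of methoxy for methyl on this aromatic carbon gives a 1.3-fold lower number from compound 2 to compound 3 (0.12 log units; within the scatter) and so the two groups cannot be told apart at this position. Putting hydroxycarbamoyl in place of 2-(hydroxycarbamoyl)ethenyl gives a 1.7-fold lower number from compound 1 to compound 3 (0.22 log units; within the scatter) and so this change cannot be told from the scatter either. No measurement shown here offers an explanation for these results. As far as these compounds go, whether an amine or a carboxylic acid on this aromatic carbon would shift the number stays open, as does the effect of a longer chain carrying the hydroxycarbamoyl group.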